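Isothiocyanate piperazine series: removing the trifluoromethyl

The source may hold more compounds than are shown below. What is called first, only, known or untested is meant among the compounds shown, and "the series" means these compounds.

Compound 3 `Cc1ccc(-c2nnc(-c3ccc(CN4CCN(CCN=C=S)CC4)c(C(F)(F)F)c3)o2)cc1Nc1nccc(-c2cccnc2)n1` gives 500 nM in a functional assay on K562 cells (Homo sapiens) for inhibition, read by MTT assay, with a stated time of 72 h (a higher number here means a weaker inhibitor, a lower number a stronger inhibitor), the lowest of the two numbers here; compound 1 `Cc1ccc(-c2nnc(-c3ccc(CN4CCN(C)CC4)cc3)o2)cc1Nc1nccc(-c2cccnc2)n1` gives 4900 nM. Compound 2 `Cc1ccc(-c2nnc(-c3ccc(C)c(C(F)(F)F)c3)o2)cc1Nc1nccc(-c2cccnc2)n1` gives > 30000 nM, which is a limit of the assay (the limit of > 30000 nM in this assay, at which 1 of the 3 values shown sits). Among the compounds with values here, the one measured step, an at least 60-fold lower number from compound 2 to compound 3 (1.77 log units; beyond the scatter), concerns the piperazine chain, not the aryl substituent. Compound 4 `Cc1ccc(-c2nnc(-c3ccc(CN4CCN(CCN=C=S)CC4)cc3)o2)cc1Nc1nccc(-c2cccnc2)n1` keeps that chain and differs from compound 3 by hydrogen in place of trifluoromethyl on an aromatic carbon. Within the data shown here, no measured step touches this position; compound 1, which also lacks the trifluoromethyl, and compound 3 differ in two places, so their values give only a loose bound. A modest weakening is expected, a 2.0-fold higher number from compound 3 to compound 4 (0.30 log units; within the scatter). Compound 4 is estimated at 1000 nM in this assay, within 300 nM to 4000 nM.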

Compound 4, half-maximal inhibitory concentration: 920 nM
Compound 4: the middle estimate sits 1.1-fold (0.04 log units) above what was measured, within the range that was stated.
By their numbers in this assay, from the lowest: compounds 3 and 4 (each within the scatter of the next); then compound 1. At a limit, above all of these: compound 2.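

In this assay, within the data shown here, hydrogen in place of trifluoromethyl on this aromatic carbon gives a 1.8-fold higher number from compound 3 to compound 4 (0.26 log units; within the scatter), the first single-change reading at this position, so with the isothiocyanate chain present the trifluoromethyl is not required. The chain change also holds without the trifluoromethyl: a 5.3-fold lower number from compound 1 to compound 4 (0.73 log units; beyond the scatter). No measured property here accounts for either step. Going by these compounds, whether the trifluoromethyl matters as little without the isothiocyanate chain stays open, as does the effect of a chlorine atom or a methoxy group on this carbon. Also open, on these data alone, is whether an amine in place of the isothiocyanate keeps the gain.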